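The compounds below may be only part of what the source reports. "The series", "measured", "known", "first", "only" and "open" are said of these compounds alone.

Measured in a functional assay on B16-F0 cells (Mus musculus) for inhibition, read by CCK-8 assay, with a stated time of 48 h; a higher number here means a weaker inhibitor, a lower number a stronger inhibitor:
- compound 1 `Cn1ccc2cc(-c3cc4nccc(-c5ccc(F)cc5)n4n3)ccc21`: 4780 nM
- compound 2 `COc1cc(-c2ccnc3cc(-c4cccc(C#N)c4)nn23)cc(OC)c1OC`: > 10000 nM (a limit, not a number)
- compound 3 `COc1cc(-c2ccnc3cc(-c4ccccc4)nn23)cc(OC)c1OC`: 4730 nM

In this assay, for the measured compounds named here, compound 3 at 4730 nM and compound 1 at 4780 nM lie within the usual scatter of each other, and they are the only two real numbers so far. The value of compound 2 is a limit.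

Compound 4 `C=Cc1ccc(-c2cc3nccc(-c4cc(OC)c(OC)c(OC)c4)n3n2)cc1` keeps compound 3 but for one change on its phenyl ring, which becomes 4-vinylphenyl: vinyl in place of hydrogen on an aromatic carbon. That puts vinyl in place of hydrogen on an aromatic carbon, para to a large group.

Going by the values given here, only one measured step touches this ring, and it involves a different group: an at least 2.1-fold lower number from compound 2 to compound 3 (0.32 log units; beyond the scatter), where cyano gives way to hydrogen. That single case hints that a group added to the ring may cost some activity, but it is thin evidence for vinyl. The expected change is therefore no clear shift beyond the scatter, with a slight lean towards a higher number: a 1.2-fold higher number from compound 3 to compound 4 (0.07 log units; within the scatter).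

The estimate for compound 4 is 5500 nM, with an expected range from 1500 nM to 15000 nM.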

Compound 4, half-maximal inhibitory concentration: 788 nM
The estimate for compound 4 lay 7.0-fold (0.84 log units) above the measured number, outside the stated range (below it).
By their numbers in this assay, from the lowest: compound 4; then compounds 3 and 1 (each within the scatter of the next). At a limit, above all of these: compound 2.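

The step on the phenyl ring shows that a group added para to a large group need not cost activity, which the cyano step alone could not show: in this assay, vinyl in place of hydrogen gives a 6.0-fold lower number from compound 3 to compound 4 (0.78 log units; beyond the scatter). Exchanging 3-cyanophenyl for 4-vinylphenyl gives an at least 12-fold lower number from compound 2 to compound 4 (1.10 log units; beyond the scatter), so the two substituted rings shown lie far apart. The value of compound 2 is a limit, not a number: the limit of > 10000 nM in this assay, at which 1 of the 4 values shown sits.

Vinyl is the only group shown at this place, and whether an ethyl group, an amine or a carboxylic acid there would give the same gain stays open. The compounds shown also give no explanation for why vinyl lowers the number.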